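Carbamate-to-amide change on the sulfonyl cap

A few compounds are considered here, and "the series" means these few. Any claim that something is new, unique, unknown or untested is made for them only; others in the source may bear on it.

Compound 1 `CCOC(=O)NS(=O)(=O)c1sc(CC(C)C)cc1-c1cccc(Cn2ccnc2)c1` carries an ethyl carbamate on the sulfonamide nitrogen. Within the data shown here, in an ADME assay on microsomes from liver (Homo sapiens) for metabolic stability, read by LC-MS, using NADPH, tested at 1 uM (a higher number here means that the compound lasts longer, a lower number that the compound disappears faster), compound 1 gives 1.02 h, the highest of the three numbers measured so far. Compound 2 `CCCCCOC(=O)NS(=O)(=O)c1sc(CC(C)C)cc1-c1cccc(Cn2ccnc2)c1` gives 0.108 h in this assay, and compound 3 `CC(C)Cc1cc(-c2cccc(Cn3ccnc3)c2)c(S(=O)(=O)NC(=O)OC2CCCC2)s1` gives 0.0933 h. Both steps away from compound 1 run downward: a 9.4-fold lower number from compound 1 to compound 2 (0.98 log units; beyond the scatter) and an 11-fold lower number from compound 1 to compound 3 (1.04 log units; beyond the scatter). Between the two larger caps the difference is small, a 1.2-fold lower number from compound 2 to compound 3 (0.06 log units; within the scatter).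

Compound 4 `CCCC(=O)NS(=O)(=O)c1sc(CC(C)C)cc1-c1cccc(Cn2ccnc2)c1` has not yet been measured in this assay. It differs from compound 1 as follows: propyl in place of ethoxy on a carbonyl carbon. The carbonyl and the amide-type nitrogen stay; an oxygen leaves and a carbon enters, with the heavy-atom count of the cap unchanged.

Among the measured compounds shown here, no measured step covers this exact exchange. The two steps from compound 1, a 9.4-fold lower number from compound 1 to compound 2 (0.98 log units; beyond the scatter) and an 11-fold lower number from compound 1 to compound 3 (1.04 log units; beyond the scatter), show that enlarging the cap came at a cost, but compound 4 does not enlarge it, so the same loss is not expected in full. A smaller downward step is expected, a 2.0-fold lower number from compound 1 to compound 4 (0.31 log units; beyond the scatter), which may still fall inside the scatter. Compound 4 is estimated at 0.5 h in this assay, with a range from 0.15 h to 1.5 h.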

Compound 4, half-life: 0.08 h
Estimate against measurement, compound 4: 6.3-fold (0.80 log units) above; the whole stated range lies above it.
By their numbers in this assay, from the lowest: compounds 4, 3 and 2 (each within the scatter of the next); then compound 1.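

Exchanging ethoxy for propyl on the carbonyl carbon leaves the heavy-atom count of the cap unchanged, yet in this assay it gives a 13-fold lower number from compound 1 to compound 4 (1.11 log units; beyond the scatter) and so matches the size of the losses seen with the larger caps; a larger cap is therefore not needed for a low number at this position. The steps to compound 4 from the two larger carbamates, a 1.2-fold lower number from compound 3 to compound 4 (0.07 log units; within the scatter) and a 1.4-fold lower number from compound 2 to compound 4 (0.13 log units; within the scatter), leave compounds 2, 3 and 4 indistinguishable here, so among the four compounds only the ethyl carbamate of compound 1 stands apart, with the propyl amide falling in the same group as the pentyl and cyclopentyl carbamates. No supporting data bear on what sets compound 1 apart from the other three.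

The compounds shown leave open how narrow this tolerance is, since a propoxy or methoxy group on the same carbonyl carbon would show whether the higher number belongs to the ethyl carbamate alone or extends to neighbouring carbamates. An ethylamino group in that place, giving a urea-type cap, would test whether an oxygen at this point can be replaced by another heteroatom.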